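A few compounds are considered here, and "the series" means these few. Any claim that something is new, unique, unknown or untested is made for them only; others in the source may bear on it.

Measured compounds:
- Compound 1, `CSc1nnc(Cc2ccc(Cl)cc2Oc2ccccc2Cl)[nH]1`, gives 132% in a functional assay on the whole organism (strain NMRI) with Mus musculus as the target, with a stated time of 60 min, at a dose of 10 mg/kg by the intraperitoneal route; on this read-out higher numbers stand for a stronger effect at the one dose given and lower numbers for a weaker effect.
- Compound 2, `CCSc1nnc(Cc2ccc(Cl)cc2Oc2ccccc2Cl)[nH]1`, gives 140% in the same assay.
- Compound 3, `CCCSc1nnc(Cc2ccc(Cl)cc2Oc2ccccc2Cl)[nH]1`, gives 125%.

Within the data shown here, compound 3 stands lowest of the three numbers, though its gap to compound 1 is within the scatter; only the step of a number 15 percentage points lower from compound 2 to compound 3 (beyond the scatter) reaches beyond it. The next compound, compound 4, `Clc1ccc(Cc2nnc(SCc3ccccc3)[nH]2)c(Oc2ccccc2Cl)c1`, differs from compound 3 in one place: phenyl in place of ethyl on a saturated chain carbon bound to a sulfur. All three measured steps concern the same chain on the sulfur. Lengthening it by one carbon gave a number 8 percentage points higher from compound 1 to compound 2 (within the scatter) and by two carbons gave a number 7 percentage points lower from compound 1 to compound 3 (within the scatter), while a number 15 percentage points lower from compound 2 to compound 3 (beyond the scatter) was the only step beyond the scatter. Among the measured compounds shown here, none of these puts a phenyl on that carbon, so the change to compound 4 has no direct precedent here. Since all changes at this carbon stayed small, the expected step in this assay for compound 4 is no change at the digits printed from compound 3 to compound 4 (within the scatter), not beyond the scatter in either direction. Compound 4 is therefore estimated at 125%, with a range from 95% to 150%.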

Compound 4, a percentage reported as activity, at one dose (the size of the read-out at that dose, not a potency): 122%
Beside the measured number, compound 4's estimate is 3 percentage points above it, and the stated range covers the measured number.
By their numbers in this assay, from the lowest: compounds 4, 3, 1 and 2 (each within the scatter of the next, the first and the last beyond it).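

In this assay, a six-membered aromatic ring of carbon can enter on the saturated chain carbon bound to the sulfur with no change beyond the scatter: going from propylsulfanyl to benzylsulfanyl gives a number 3 percentage points lower from compound 3 to compound 4 (within the scatter). Set against the shorter chains, the same ring gives a number 10 percentage points lower from compound 1 to compound 4 (within the scatter) and a number 18 percentage points lower from compound 2 to compound 4 (beyond the scatter), leaving compound 2 as the only one separated from compound 4 by more than the scatter. No measurement on hand accounts for these numbers.

Still open, from the compounds shown here alone, is how a longer chain such as butyl, or a chain ending in an amine or a carboxylic acid, would behave on the sulfur. Each number also gives the size of the effect at one dose, and says nothing about how the potencies of these compounds compare.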